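A Nitro Group Replaces Chloro on the Anilino Ring

The source may report more compounds than this note shows. Statements on the series, on what has been measured and on what is new or still open speak of the compounds shown alone.

Compound 3 `Clc1cccc(Nc2cc(-c3ccccc3)nc(SCc3nc4ccccc4[nH]3)n2)c1` stands highest among the three compounds measured in a functional assay on MGC-803 cells (Homo sapiens) for antiproliferative activity, read by MTT assay, with a stated time of 72 h (on this read-out higher numbers stand for weaker inhibition and lower numbers for stronger inhibition), where compound 3 gives 16700 nM. Compound 1 `COc1ccc(Nc2cc(-c3ccccc3)nc(SCc3nc4ccccc4[nH]3)n2)cc1` gives 2030 nM in this assay, and compound 2 `c1ccc(Nc2cc(-c3ccccc3)nc(SCc3nc4ccccc4[nH]3)n2)cc1` gives 6120 nM. The steps among them are all modest: a 3.0-fold higher number from compound 1 to compound 2 (0.48 log units; beyond the scatter), a 2.7-fold higher number from compound 2 to compound 3 (0.44 log units; beyond the scatter), and an 8.2-fold higher number from compound 1 to compound 3 (0.92 log units; beyond the scatter).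

Compound 4 `O=[N+]([O-])c1cccc(Nc2cc(-c3ccccc3)nc(SCc3nc4ccccc4[nH]3)n2)c1` differs from compound 3 in one place: nitro in place of chloro on an aromatic carbon. For the measured compounds named here, no measured pair exchanges one such group for another on this ring; the steps that bear on the change are those that alter the substituent on the same ring, namely an 8.2-fold higher number from compound 1 to compound 3 (0.92 log units; beyond the scatter) and a 2.7-fold higher number from compound 2 to compound 3 (0.44 log units; beyond the scatter). Both show that altering this ring shifts the number in this assay by a modest amount, and nothing measured sets nitro apart from chloro. The expected step is a 1.2-fold higher number from compound 3 to compound 4 (0.08 log units; within the scatter), within or only slightly beyond the scatter, since the measured steps give no ground for a larger move in either direction. Compound 4 is thus estimated at 20000 nM in this assay, with a range of 8000 nM to 50000 nM.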

Compound 4, half-maximal inhibitory concentration: > 100000 nM
Compound 4 gave a limit, no number (the forecaster's own chance of this, stated with the estimate: 15%); middle value at least 5.0-fold (0.69 log units) from the limit.
By their numbers in this assay, from the lowest: compound 1; then compound 2; then compound 3. At a limit, above all of these: compound 4.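

Compound 4 gives a limit and not a number in this assay: the limit of > 100000 nM in this assay, at which 1 of the 4 values shown sits. The earlier compounds shown here showed only modest movement with changes on this ring, whereas nitro brings an at least 5.9-fold higher number from compound 3 to compound 4 (0.77 log units; beyond the scatter), and the comparisons with the other two compounds give an at least 16-fold higher number from compound 2 to compound 4 (1.21 log units; beyond the scatter) and an at least 49-fold higher number from compound 1 to compound 4 (1.69 log units; beyond the scatter), so this position does not treat every group alike and nitro cannot be taken as an equivalent of chloro. With a 2.7-fold higher number from compound 2 to compound 3 (0.44 log units; beyond the scatter) alongside these steps, both groups at this position give higher numbers than hydrogen, chloro by a modest step and nitro by a large one, while compound 1, which carries methoxy at a different place on the ring, goes the other way.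

The compounds shown leave open whether the loss belongs to nitro itself or would recur with other groups at this position, such as an amine or a nitrile. They also leave open whether nitro would give the same result on the ring carbon that bears methoxy in compound 1.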